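The source may report more compounds than this note shows. Statements on the series, on what has been measured and on what is new or still open speak of the compounds shown alone.

Measured so far:
Compound 1, `O=c1cc(CSC(=S)N2CCOCC2)oc2cc(Cl)ccc12`: in a functional assay on LM7 cells (Homo sapiens) for antiproliferative activity, read by MTT assay, with a stated time of 72 h (a lower number here means a stronger inhibitor, a higher number a weaker inhibitor), compound 1 gives > 25000 nM, which is a limit of the assay and not a number.
Compound 2, `CC(C)N(C(=S)SCc1cc(=O)c2ccccc2o1)C(C)C`: in this assay compound 2 gives > 25000 nM, again a limit of the assay.

For the measured compounds named here, compound 2 therefore stands at the limit in this assay; no number is known for it, and the one other value shown is a limit as well (the limit of > 25000 nM in this assay, at which 2 of the 2 values shown sit). Going by the values given here, no step between two measured compounds with a number on both ends is available, so nothing can be said about the size of any measured change.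

Compound 3, `O=c1cc(CSC(=S)N2CCOCC2)oc2ccccc12`, differs from compound 2 by morpholin-4-yl in place of diisopropylamino on a thiocarbonyl carbon. With both measured values sitting at the limit, the step that the limit leaves unreadable from compound 2 to compound 3 is expected to be none beyond the scatter, and compound 3 is expected to come out at the limit too. For compound 3 in this assay the estimate is 35000 nM, with a range from 12000 nM to 100000 nM.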

Compound 3, half-maximal inhibitory concentration: 25200 nM
Compound 3: the middle estimate sits 1.4-fold (0.14 log units) above what was measured; the range from low to high includes it.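

The steps from compound 1 and from compound 2 to compound 3 cannot be read, because compounds 1 and 2 each sit at a limit and not at a number: the limit of > 25000 nM in this assay, at which 2 of the 3 values shown sit.

The compounds shown leave open how much either change, hydrogen in place of chloro or morpholin-4-yl in place of diisopropylamino, alters activity.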